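The source may report more compounds than this note shows. Statements on the series, on what has been measured and on what is new or still open speak of the compounds shown alone.

Of the compounds shown here, three have so far been measured in a functional assay, read by spectrophotometry, with a stated time of 15 min, tested at 20 ug/mL; on this read-out higher numbers stand for a stronger effect at the one concentration tested and lower numbers for a weaker effect. Compound 1 `Cc1ccc(-c2csc(N/N=C/c3ccc(Cl)cc3Cl)n2)cc1` gives 76.2% in this assay. Compound 3 `Cc1ccc(-c2csc(N/N=C/c3cccs3)n2)cc1` gives 79.6% in this assay, a number that lies within the usual scatter of the number for compound 1, so the two cannot be separated. Compound 2 `COC(=O)c1cc(-c2csc(N/N=C/c3ccc(Cl)cc3Cl)n2)ccc1OCc1ccccc1` gives 58.9% in this assay, which lies beyond the scatter and lower than compound 1. On these numbers compound 1 stands second of the three, close to compound 3 and clearly apart from compound 2.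

Compound 4 `Clc1ccc(/C=N/Nc2nc(-c3ccccc3)cs2)c(Cl)c1` has not yet been measured. It differs from compound 1 in one place: hydrogen in place of methyl on an aromatic carbon. Cut one bond further out, the change reads 4-methylphenyl to phenyl, and it sits on an aromatic carbon of a six-membered aromatic ring of carbon only, para to a large group. Within the data shown here, no measured pair differs in this way, so the numbers in hand show nothing about what this change does in this assay. A change this small is expected to give a step within the scatter, or at most a modest fall. The expected step of a number 6.2 percentage points lower from compound 1 to compound 4 (within the scatter) is accordingly kept small. Compound 4 is estimated at 70% in this assay, with a range from 54% to 84%.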

Compound 4, a percentage reported as inhibition, at one concentration (the size of the read-out at that concentration, not a potency): 78.1%
Beside the measured number, compound 4's estimate is 8.1 percentage points below it, within the range that was stated.
By their numbers in this assay, from the lowest: compound 2; then compounds 1, 4 and 3 (each within the scatter of the next).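

Hydrogen in place of methyl on an aromatic carbon gives a number 1.9 percentage points higher from compound 1 to compound 4 (within the scatter) in this assay, and this is the first measured reading of what this change does. At this place, on an aromatic carbon of a six-membered aromatic ring of carbon only, para to a large group, going from 4-methylphenyl to phenyl leaves the read-out at the one concentration tested indistinguishable, so for this pair the methyl is not required for the effect seen with compound 1. Nothing measured on these compounds accounts for the result, and no reason for it can be given.

As far as these compounds go, this single pair speaks only for methyl and hydrogen, so what a methoxy group, an amine or a carboxylic acid at the same place would do in this assay remains open. From the compounds shown here alone, it also remains open whether the same change would give a step of similar size where the other end of the molecule differs, as it does in compound 3, or at other concentrations.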